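This account rests on a few compounds, and the source may have more. Where it says the series, first, only, none or still open, it means among the compounds named here.

Measured so far:
compound 1 `CCCSc1nc(N/N=C/c2cccnc2)c2nnn(Cc3ccccc3)c2n1` — > 64000 nM
compound 2 `CCCSc1nc(N/N=C(\C)c2ccccc2O)c2nnn(Cc3ccc(O)cc3)c2n1` — 15900 nM

On these data alone, compound 1 stands only as a limit in a functional assay on ECa-109 cells (Homo sapiens) for antiproliferative activity, read by MTT assay, with a stated time of 72 h; on this read-out lower numbers stand for stronger inhibition and higher numbers for weaker inhibition: the value > 64000 nM is the limit of the assay and not a number, so its true position is unknown beyond that (the limit of > 64000 nM in this assay, at which 1 of the 2 values shown sits). Going by the values given here, compound 2, in this assay, gives a measured number at 15900 nM; no step between these two is computed, as they differ in more than one place, and the two values show only that compound 2 lies inside the measured range while compound 1 does not.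

Compound 3 `CCCSc1nc(N/N=C(\C)c2ccccc2)c2nnn(Cc3ccccc3)c2n1` has not yet been measured in this assay. It differs from compound 1 by a group of 9 heavy atoms (8 carbon, 1 nitrogen; one six-membered aromatic ring of carbon only) in place of a group of 8 heavy atoms (6 carbon, 2 nitrogen; one six-membered aromatic ring with 1 hetero atom), on a nitrogen on an aromatic ring. Compound 1 stands at a limit, so the size of the step cannot be read from a measured pair. Any expectation rests on compound 2, which carries the same kind of double bond with an extra carbon and a carbon-only ring and gives 15900 nM.

Compound 3 is therefore expected to come in as a measurable number, with the expected step of an at least 2.1-fold lower number from compound 1 to compound 3 (0.32 log units; beyond the scatter) pointing toward stronger inhibition, at about 30000 nM, between 8000 nM and 64000 nM.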

Compound 3, half-maximal inhibitory concentration: 32200 nM
Compound 3: the middle estimate sits 1.1-fold (0.03 log units) below what was measured, and the stated range covers the measured number.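

In this assay, compound 3 gives a number inside the measured range, so the group of 9 heavy atoms with its six-membered aromatic ring of carbon only, on a nitrogen on an aromatic ring, is compatible with measurable antiproliferative activity where the group of 8 heavy atoms with its ring hetero atom is not shown to be. Compound 1 stands at a limit of the assay, not at a number: the limit of > 64000 nM in this assay, at which 1 of the 3 values shown sits.

On these data alone, the change therefore reads only as a floor, an at least 1.9-fold lower number from compound 1 to compound 3 (0.29 log units; that floor lies within the scatter), and its true size remains unknown; the floor alone does not place the step beyond the usual scatter.

The swap alters the ring hetero atom and the heavy-atom count together, so the pair does not show which of the two goes with the measured number. As far as these compounds go, how an amine or a carboxylic acid on the carbon-only ring, or a longer chain in place of the propyl chain on sulfur, would read in this assay also stays open.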